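Chloro to Fluoro on a Macaque Exposure Series

The compounds below may be only part of what the source reports. "The series", "measured", "known", "first", "only" and "open" are said of these compounds alone.

Two compounds built on a shared core have been run in an ADME assay on the whole organism (Macaca fascicularis) for pharmacokinetics, read by LC-MS, using cassette dosing, at a dose of 1 mg/kg by the oral route; on this read-out lower numbers stand for lower exposure and higher numbers for higher exposure at the dose given. Compound 1 `C[C@H](c1ccc(-c2cc(Cl)ccc2-c2nc(=O)o[nH]2)cc1)N(CC1CC1)c1nc2c(C(=O)O)cccc2o1` gives 976 nM. Compound 2 `CCCCN(c1nc2c(C(=O)O)cccc2o1)[C@H](C)c1ccc(-c2cc(Cl)ccc2-c2nc(=O)o[nH]2)cc1` gives 677 nM. For the measured compounds named here, the one measured step, a 1.4-fold lower number from compound 1 to compound 2 (0.16 log units; within the scatter), concerns the chain on the saturated carbon bound to the ring nitrogen, and it leaves the two compounds within the scatter of each other, so neither stands apart on this read-out.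

Compound 3 `CCCCN(c1nc2c(C(=O)O)cccc2o1)[C@H](C)c1ccc(-c2cc(F)ccc2-c2nc(=O)o[nH]2)cc1` differs from compound 2 by fluoro in place of chloro on an aromatic carbon. Going by the values given here, this halogen exchange on the aromatic ring is the only difference between compound 2 and compound 3. Among the compounds with values here, the measured step of a 1.4-fold lower number from compound 1 to compound 2 (0.16 log units; within the scatter) touches a different site and does not bear directly on it, and the data hold no step of this kind elsewhere. With nothing to point in either direction, the step of a 1.0-fold higher number from compound 2 to compound 3 (0.00 log units; within the scatter) is expected to stay within the scatter. Compound 3 is therefore estimated at 680 nM, with a range from 300 nM to 1500 nM.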

Compound 3, maximal plasma concentration: 1180 nM
For compound 3 the middle estimate is 1.7-fold (0.24 log units) below the measured one, within the range that was stated.
By their numbers in this assay, from the lowest: compounds 2, 1 and 3 (each within the scatter of the next).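

Read in this assay, the exchange of chloro for fluoro gives a 1.7-fold higher number from compound 2 to compound 3 (0.24 log units; within the scatter), and this is the first reading at this aromatic carbon, meta to a large group and para to a group of 6 heavy atoms. The earlier pair differed only at a chain elsewhere on the shared core. With that chain held fixed, the two halogens cannot be told apart on this read-out, so the series shows that this place accepts fluoro as well as chloro without leaving the scatter. Nothing available bears on the reason for this result, and a single pair sets no trend for the position.

The compounds shown leave open whether a group other than a halogen at this carbon, such as methyl, methoxy or a nitrile, would also stay within the scatter of compound 2. For the compounds shown here, they also leave open whether the same exchange of chloro for fluoro would read alike with the cyclopropyl of compound 1 on the chain, since only one such pair is at hand.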